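Nitro for Phenoxy on the Pendant Ring of Compound 3

The source may report more compounds than this note shows. Statements on the series, on what has been measured and on what is new or still open speak of the compounds shown alone.

Compound 3 `Cc1cnc2sn(-c3ccc(Oc4ccccc4)cc3)c(=O)c2c1` carries a phenoxy group on the aromatic ring attached to its core, and in an assay for inhibition of histone acetyltransferase KAT2B (Homo sapiens), read by fluorescence (on this read-out lower numbers stand for stronger inhibition and higher numbers for weaker inhibition), compound 3 has "not determined" (no result reported), so it stands nowhere on the numbers shown. Compound 4 `Cc1cnc2sn(-c3ccc([N+](=O)[O-])cc3)c(=O)c2c1` keeps the same core and differs from compound 3 in one place: nitro in place of phenoxy on an aromatic carbon.

The two measured compounds give some orientation. Compound 1 `O=c1c2cc([N+](=O)[O-])cnc2sn1-c1ccc([N+](=O)[O-])cc1` carries two nitro groups, and in this assay compound 1 gives 15800 nM. Compound 2 `O=c1c2cccnc2sn1-c1ccc([N+](=O)[O-])cc1` keeps only the nitro on the pendant ring, and in this assay compound 2 gives 2990 nM. For the measured compounds named here, the single measured step, a 5.3-fold lower number from compound 1 to compound 2 (0.72 log units; beyond the scatter), concerns a nitro on the core rather than on the pendant ring, so it does not bear directly on the change from compound 3 to compound 4. Going by the values given here, compound 4 shares the nitro-bearing pendant ring of compound 2 and differs from it only by a methyl on the core; no step covers that difference either.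

Compound 4 is therefore expected to land near compound 2, about 3500 nM, within a range from 800 nM to 15000 nM.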

Compound 4, half-maximal inhibitory concentration: 2720 nM
Compound 4: middle estimate off by 1.3-fold (0.11 log units), on the high side; the range from low to high includes it.
By their numbers in this assay, from the lowest: compounds 4 and 2 (each within the scatter of the next); then compound 1.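

In this assay, methyl in place of hydrogen on the aromatic carbon of the shared core gives a 1.1-fold lower number from compound 2 to compound 4 (0.04 log units; within the scatter), so this read-out does not separate these two groups at this position. Methyl in place of nitro on that same carbon gives a 5.8-fold lower number from compound 1 to compound 4 (0.76 log units; beyond the scatter), a step of similar size to the one already seen with hydrogen in place of nitro, a 5.3-fold lower number from compound 1 to compound 2 (0.72 log units; beyond the scatter), so among the three groups tried there, nitro alone stands apart, with the weaker inhibition. The step from compound 3 to compound 4 cannot be read, as compound 3 has no number, and so the result says nothing about phenoxy against nitro on the pendant ring.

No measurement shown here offers a reason for these numbers. As far as these compounds go, it remains open whether other groups on that core carbon, such as an amine, a carboxylic acid or a longer chain like propyl, would also match hydrogen and methyl or would instead shift the number, and how the pendant ring would respond to a group such as methoxy in place of nitro.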